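Benzyl substituent swap across two Substance-P receptor cores

The compounds below may be only part of what the source reports. "The series", "measured", "known", "first", "only" and "open" are said of these compounds alone.

Measured compounds:
compound 1, `Cc1cc2c(-c3ccccc3)c(NC(=O)N(C)Cc3ccccc3Cl)n(C)c(=O)c2cc1C`, in an assay on IM-9 cells for binding affinity to Substance-P receptor (Homo sapiens) (on this read-out lower numbers stand for stronger inhibition and higher numbers for weaker inhibition), gives 4.2 nM
compound 2, `Cc1cc(C)cc(CN(C)C(=O)Nc2c(-c3ccccc3)c3cc(C)c(C)cc3c(=O)n2C)c1`, in this assay gives 28 nM
compound 3, `CN(Cc1ccccc1Cl)C(=O)c1c(-c2ccc(F)cc2)c2cccnc2c(=O)n1C`, in this assay gives 32 nM

Compound 1 and compound 2 share one core and differ by a single change, (3,5-dimethylphenyl in place of 2-chlorophenyl on a saturated chain carbon bound to an amide-type nitrogen). That change made a step of a 6.7-fold higher number from compound 1 to compound 2 (0.82 log units; beyond the scatter). Compound 3 carries a different core; how the core of compound 3 differs from the core of compound 1 is not broken down here. Compound 3 and compound 2 give numbers within the scatter of each other, while compound 1 gives a lower number than both.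

Compound 4, `Cc1cc(C)cc(CN(C)C(=O)c2c(-c3ccc(F)cc3)c3cccnc3c(=O)n2C)c1`, is not yet measured. It differs from compound 3 by 3,5-dimethylphenyl in place of 2-chlorophenyl on a saturated chain carbon bound to an amide-type nitrogen, the same change that was made from compound 1 to compound 2. Because the step of a 6.7-fold higher number from compound 1 to compound 2 (0.82 log units; beyond the scatter) was modest and beyond the scatter, compound 4 is expected to give a higher number than compound 3, with a step estimated at a 5.0-fold higher number from compound 3 to compound 4 (0.70 log units; beyond the scatter), though the size of that step rests on a single pair on a different core. The expected value for compound 4 in this assay is 160 nM, estimated to lie between 50 nM and 500 nM.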

Compound 4, half-maximal inhibitory concentration: 5.1 nM
Compound 4: middle estimate off by 31-fold (1.50 log units), on the high side; measured number below the stated range.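

In this assay, the move from 2-chlorobenzyl to 3,5-dimethylbenzyl gave a 6.3-fold lower number from compound 3 to compound 4 (0.80 log units; beyond the scatter) on the core of compound 3, and this step runs in the opposite direction to the one seen on the core of compound 1: the same change on two cores in this assay, a 6.7-fold higher number (0.82 log units; beyond the scatter) from compound 1 to compound 2 and a 6.3-fold lower number (0.80 log units; beyond the scatter) from compound 3 to compound 4, 42-fold (1.62 log units) apart, beyond the scatter of two such steps. The result shows that, in this series, the direction of this change could not be carried from one core to the other, and that a single pair on one core was a poor guide to a pair on another. It does not show which part of the cores reverses the step, as the difference between them is not broken down, and two pairs cannot show how either core would respond to other changes.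

The compounds shown leave open how a plain benzyl, a methoxybenzyl or a longer chain such as phenethyl would behave on either core. They also leave open which of the two directions, if either, would hold on a further core.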